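The source may report more compounds than this note shows. Statements on the series, on what has been measured and on what is new or still open speak of the compounds shown alone.

In a functional assay on HepG2 cells (Homo sapiens) for cytotoxicity, read by spectrophotometry, with a stated time of 72 h (on this read-out lower numbers stand for stronger inhibition and higher numbers for weaker inhibition), compound 2 `COc1ccc(-n2c(-c3cc(OC)c(OC)c(OC)c3)cccc2=O)cc1` gives 5740 nM and compound 1 `COc1ccc(-n2c(-c3cc(OC)c(OC)c(OC)c3)cccc2=O)cc1OCc1ccccc1` gives 3040 nM so the two stand level within the usual scatter. Compared with compound 2, compound 3 `COc1cc(-c2cccc(=O)n2-c2ccc(F)cc2)cc(OC)c1OC` carries fluoro in place of methoxy on an aromatic carbon, para to a large group fluoro in place of methoxy on an aromatic carbon on the shared core. Within the data shown here, the only measured step is a 1.9-fold higher number from compound 1 to compound 2 (0.28 log units; within the scatter) and it involves a different group, so it offers weak guidance at best. No step beyond the scatter is therefore expected in this assay in either direction. The estimated change is a 1.0-fold higher number from compound 2 to compound 3 (0.02 log units; within the scatter) and no more than that. Compound 3 is expected at 6000 nM with an estimated range from 2500 nM to 15000 nM in all.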

Compound 3, half-maximal inhibitory concentration: > 100000 nM
Compound 3 ended at the assay's limit (the forecaster's own chance of this, stated with the estimate: 5%); middle value at least 16-fold (1.22 log units) from the limit.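

In this assay, the change from 4-methoxyphenyl to 4-fluorophenyl gives an at least 17-fold higher number from compound 2 to compound 3 (1.24 log units; beyond the scatter). Among these compounds, this is the first step beyond the scatter, so this position responds strongly to a small change, which the earlier pair, differing elsewhere, could not show. The number for compound 3 is a limit of the assay and not an exact value: the limit of > 100000 nM in this assay, at which 1 of the 3 values shown sits.

Only one replacement of the methoxy is shown, so it stays open whether losing the methoxy or gaining the fluoro matters more. An ethoxy group, a hydroxy group or an amine at this position could help separate the two.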